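Adding butyl to the 2-acetoxyethyl chain of compound 2

The compounds below may be only part of what the source reports. "The series", "measured", "known", "first", "only" and "open" are said of these compounds alone.

Of the compounds shown here, three sharing one core have been measured in a functional assay on HeLa cells (Homo sapiens) for cytotoxicity, read by MTT assay; a lower number here means a stronger inhibitor, a higher number a weaker inhibitor. Compound 1 `CC(C)=CC[C@@H](OC(=O)c1ccco1)C1=CC(=O)c2c(O)ccc(O)c2C1=O` gives 80300 nM, compound 3 `COCCO[C@H](CC=C(C)C)C1=CC(=O)c2c(O)ccc(O)c2C1=O` gives 62400 nM, and compound 2 `CC(=O)OCCC(=O)O[C@H](CC=C(C)C)C1=CC(=O)c2c(O)ccc(O)c2C1=O` gives 17300 nM. Compound 2 therefore stands as the strongest inhibitor of the three, with the lowest number in the set.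

Compound 4 `CCCCC(CC(=O)O[C@H](CC=C(C)C)C1=CC(=O)c2c(O)ccc(O)c2C1=O)OC(C)=O` departs from compound 2 in one place: butyl in place of hydrogen on a saturated chain carbon bound to an oxygen next to a carbonyl group and a saturated chain carbon. The change turns 2-acetoxyethyl into 2-acetoxyhexyl. Within the data shown here, no measured pair makes this change, so the evidence is indirect. Exchanging the whole group on the shared core gave a 4.6-fold lower number from compound 1 to compound 2 (0.67 log units; beyond the scatter) and a 3.6-fold higher number from compound 2 to compound 3 (0.56 log units; beyond the scatter), both modest, while a 1.3-fold lower number from compound 1 to compound 3 (0.11 log units; within the scatter) stayed within the scatter. These steps replaced the group outright, whereas compound 4 keeps the acetoxy group of compound 2 and adds a butyl to its chain. A step no larger than those modest ones therefore seems likely, and the data give no firm direction. The expected result is a 1.2-fold lower number from compound 2 to compound 4 (0.06 log units; within the scatter), which amounts to no clear shift beyond the scatter. For compound 4 the estimated value in this assay is 15000 nM, with an expected range of 5500 nM to 42000 nM.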

Compound 4, half-maximal inhibitory concentration: 73500 nM
The estimate for compound 4 lay 4.9-fold (0.69 log units) below the measured number; the whole stated range lies below it.
By their numbers in this assay, from the lowest: compound 2; then compounds 3, 4 and 1 (each within the scatter of the next).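

In this assay, butyl in place of hydrogen on a saturated chain carbon bound to an oxygen gives a 4.2-fold higher number from compound 2 to compound 4 (0.63 log units; beyond the scatter), a modest step beyond the scatter. The earlier steps shown here replaced the whole group, whereas this one keeps the acetoxy group and changes only the chain, which shows that this carbon does not tolerate butyl without a cost in this assay. Measured against the furan-2-yl ester, 2-acetoxyhexyl gives a 1.1-fold lower number from compound 1 to compound 4 (0.04 log units; within the scatter), a step within the scatter, so the gain that compound 2 held over compound 1 does not survive in compound 4. Nothing available explains why the added butyl has this effect.

Only hydrogen and butyl are shown on this carbon, so it remains open whether a methyl or an ethyl there would keep the number of compound 2 or whether the step already appears with a shorter chain. Also open, going by these compounds, is how an amine or a carboxylic acid at the end of that chain would read out in this assay.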